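Benzyloxy for hydroxyphenylcarbonyl on the methylated core

The source may hold more compounds than are shown below. What is called first, only, known or untested is meant among the compounds shown, and "the series" means these compounds.

Working notes on a short series sharing one core, read in an ADME assay on MT4 cells (Homo sapiens) for cytotoxicity, read by MTT assay, with a stated time of 5 days; on this read-out higher numbers stand for lower toxicity in this test and lower numbers for higher toxicity in this test. Compound 1 `N#Cc1ccc(Nc2nccc(Oc3ccc(C(=O)c4ccc(O)cc4)cc3)n2)cc1` gives 19400 nM. Compound 2 `N#Cc1ccc(Nc2nccc(Oc3ccc(OCc4ccccc4)cc3)n2)cc1` reaches only a limit of the assay, > 316000 nM. Compound 3 `Cc1cnc(Nc2ccc(C#N)cc2)nc1Oc1ccc(C(=O)c2ccc(O)cc2)cc1` likewise reaches only a limit, > 295000 nM. Of the three values shown, compound 3 therefore stands at the upper edge without a number, and one further value is also a limit (the limit of > 295000 nM in this assay, at which 1 of the 3 values shown sits, (the limit of > 316000 nM in this assay, at which 1 of the 3 values shown sits)).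

Two measured steps exist. an at least 16-fold higher number from compound 1 to compound 2 (1.21 log units; beyond the scatter). an at least 15-fold higher number from compound 1 to compound 3 (1.18 log units; beyond the scatter). Both are large and beyond the scatter.

Compound 4 `Cc1cnc(Nc2ccc(C#N)cc2)nc1Oc1ccc(OCc2ccccc2)cc1` is not yet measured. It differs from compound 3 by benzyloxy in place of (4-hydroxyphenyl)carbonyl on an aromatic carbon. The same exchange, made on compound 1, gave the step from compound 1 to compound 2, so the bearing step is large and points upward. Compound 3 is already at a limit, so the expected step that the limit leaves unreadable from compound 3 to compound 4 cannot produce a readable number; compound 4 is expected to report only a limit again in this assay. As a working estimate compound 4 is expected at 400000 nM, within 150000 nM to 1200000 nM.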

Compound 4, half-maximal cytotoxic concentration: 170000 nM
Estimate against measurement, compound 4: 2.4-fold (0.37 log units) above; the range from low to high includes it.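

On the methylated core, benzyloxy in place of (4-hydroxyphenyl)carbonyl gives an at least 1.7-fold lower number from compound 3 to compound 4 (0.23 log units; that floor lies within the scatter) in this assay, and compound 4 has a readable number where compound 3 has only a limit. The large upward step seen with this exchange on the core of compound 1 is therefore not repeated on the methylated core, so the exchange does not carry over between the two cores: the same change on two cores in this assay, an at least 16-fold higher number (1.21 log units; beyond the scatter) from compound 1 to compound 2 and an at least 1.7-fold lower number (0.23 log units; that floor lies within the scatter) from compound 3 to compound 4, at least 28-fold (1.45 log units) apart, beyond the scatter of two such steps. Read the other way round, methyl in place of hydrogen on an aromatic carbon also behaves differently once benzyloxy is present, giving an at least 1.8-fold lower number from compound 2 to compound 4 (0.26 log units; that floor lies within the scatter) rather than the large upward step seen with (4-hydroxyphenyl)carbonyl: the same change on two cores in this assay, an at least 15-fold higher number (1.18 log units; beyond the scatter) from compound 1 to compound 3 and an at least 1.8-fold lower number (0.26 log units; that floor lies within the scatter) from compound 2 to compound 4, at least 28-fold (1.45 log units) apart, beyond the scatter of two such steps.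

As far as these compounds go, both new steps are floors set by the limits of compound 2 and compound 3, so their true sizes remain open. Also open, from the compounds shown here alone, is whether a carboxylic acid, an amine or a longer chain on the same aromatic carbon of the methylated core would give a readable number like compound 4 or only a limit like compound 3.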